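This account rests on a few compounds, and the source may have more. Where it says the series, first, only, none or still open, it means among the compounds named here.

Compound 1 `Nc1cc(N)c2nc(-c3ccccc3)c(Oc3ccc(Cl)c(Cl)c3)nc2c1` was examined in a functional assay on UACC-257 cells (Homo sapiens) for inhibition, read by sulforhodamine B assay, with a stated time of 48 h (on this read-out higher numbers stand for lower toxicity in this test and lower numbers for higher toxicity in this test), where the value returned for compound 1 is only a limit of the assay, < 100000 nM. Two further compounds sharing the core of compound 1 give numbers in this assay: compound 2 `CCOC(=O)[C@H](CCC(=O)O)NC(=O)c1ccc(Sc2nc3cc(N)cc(N)c3nc2-c2ccccc2)cc1` gives 95500 nM, and compound 3 `COc1cc(CNc2nc3cc(N)cc(N)c3nc2-c2ccccc2)cc(OC)c1OC` gives 27500 nM. Compound 1 thus stands at the limit, (the limit of < 100000 nM in this assay, at which 1 of the 3 values shown sits), and the numbers for compound 2 and compound 3 show where substituted forms of this core have fallen in this assay.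

The compound yet to be measured, compound 4 `Nc1cc(N)c2nc(-c3ccccc3)c(Sc3ccc(F)cc3)nc2c1`, differs from compound 1 in one place: (4-fluorophenyl)sulfanyl in place of 3,4-dichlorophenoxy on an aromatic carbon, the change being (4-fluorophenyl)sulfanyl in place of 3,4-dichlorophenoxy on an aromatic carbon, the place being on an aromatic carbon of a six-membered aromatic ring with two nitrogen, part of a fused system of two rings, next to the ring nitrogen and ortho to a phenyl group. Within the data shown here, no step between two measured compounds is available to size this change. Since compound 1 offers only a limit, the step from compound 1 to compound 4 that this estimate implies, a step that the limit leaves unreadable from compound 1 to compound 4, is expected to be modest and is not taken as a firm direction. Compound 4 is estimated at 50000 nM, within a range of 15000 nM to 150000 nM.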

Compound 4, concentration lethal to 50% of the cells: 60300 nM
Compound 4: middle estimate off by 1.2-fold (0.08 log units), on the low side; the measured number falls inside the stated range.
By their numbers in this assay, from the lowest: compound 3; then compounds 4 and 2 (each within the scatter of the next).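

No step from compound 1 to compound 4 can be read in this assay, because the value for compound 1 is a limit and not a number: the limit of < 100000 nM in this assay, at which 1 of the 4 values shown sits.

The compounds shown leave open how far, and in which direction, (4-fluorophenyl)sulfanyl in place of 3,4-dichlorophenoxy on an aromatic carbon moves the value in this assay.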